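Series notes: amide methyl to hydrogen, compound 2 to 4

The source may report more compounds than this note shows. Statements on the series, on what has been measured and on what is new or still open speak of the compounds shown alone.

Measured compounds:
In a functional assay on A549 cells (Homo sapiens) for antiproliferative activity, read by MTT assay, with a stated time of 48 h (a higher number here means a weaker inhibitor, a lower number a stronger inhibitor), compound 1 `CN1C(=O)C2(C(C#N)=C(N)Oc3cc4oc(-c5ccccc5)cc(=O)c4c(O)c32)c2ccccc21` gives > 50000 nM, a limit of the assay.
In this assay compound 2 `CN1C(=O)C2(C(C#N)=C(N)Oc3cc4oc(-c5ccccc5)cc(=O)c4c(O)c32)c2cccc(Cl)c21` gives > 50000 nM, also a limit.
In this assay compound 3 `CCN1C(=O)C2(C(C#N)=C(N)Oc3cc4oc(-c5ccccc5)cc(=O)c4c(O)c32)c2cc(C)ccc21` gives > 50000 nM, again a limit.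

Compound 2 thus stands at the limit of > 50000 nM in this assay, at which 3 of the 3 values shown sit; nothing separates it from compounds 1 and 3. Within the data shown here, the one single-point comparison, a step that the two limits leave unreadable from compound 1 to compound 2, is unreadable because the limit of > 50000 nM in this assay, at which 3 of the 3 values shown sit, covers both ends.

Compound 4 `N#CC1=C(N)Oc2cc3oc(-c4ccccc4)cc(=O)c3c(O)c2C12C(=O)Nc1c(Cl)cccc12` differs from compound 2 by hydrogen in place of methyl on an amide-type nitrogen in a ring. Among the measured compounds shown here, no measured step concerns this change, and the only measured step gives no size. The expected step that the limit leaves unreadable from compound 2 to compound 4 is therefore no readable change, with compound 4 most likely staying at the limit. Compound 4 is estimated at 60000 nM, with a range from 20000 nM to 200000 nM.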

Compound 4, half-maximal inhibitory concentration: > 50000 nM
Compound 4 was reported as a limit; the forecaster's own chance of this, stated with the estimate: 80%; the middle value lies beyond the limit too.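

No step can be read between compound 2 and compound 4, because both stand at a limit: the limit of > 50000 nM in this assay, at which 4 of the 4 values shown sit.

The compounds shown leave open whether hydrogen in place of methyl on the amide-type nitrogen changes activity in this assay.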